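Working notes: cytotoxicity screen, step from compound 1 to compound 3

The source may hold more compounds than are shown below. What is called first, only, known or untested is meant among the compounds shown, and "the series" means these compounds.

Measured so far:
compound 1 `Cc1nc(-c2cccc(C(=O)N3CCCC(C(=O)Nc4ccc(Cl)cc4)C3)c2)no1` — 0%
compound 2 `COC(=O)c1cc(-c2cccc(NC(=O)C3CCCN(C(=O)c4cc(C(F)(F)F)cc(C(F)(F)F)c4)C3)c2)co1` — 0%

In an ADME assay on PC-3 cells (Homo sapiens) for cytotoxicity, read by WST assay, tested at 100 uM (on this read-out lower numbers stand for less inhibition and higher numbers for more inhibition at the one concentration tested (going by the name of the read-out)), compound 1 gives 0% and compound 2 gives 0%. Compound 1 stands level with compound 2 at the digits shown, the two values lying within the scatter, so no order between them can be read. Within the data shown here, the two compounds differ in more than one place, and no single-point step between measured compounds is available.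

Compound 3 `CCN(CC)S(=O)(=O)c1cccc(C(=O)N2CCCC(C(=O)Nc3ccc(Cl)cc3)C2)c1` differs from compound 1 in one place: diethylsulfamoyl in place of 5-methyl-1,2,4-oxadiazol-3-yl on an aromatic carbon. The group that enters, diethylsulfamoyl, sits on the same aromatic carbon that the leaving group occupied, so the rest of compound 1 is kept.

In this assay the step of a number 2 percentage points higher from compound 1 to compound 3 (within the scatter) is expected to be none beyond the scatter, because compound 1 at 0% and compound 2 at 0% stand level with each other despite unrelated peripheral groups. Compound 3 is estimated at 2%, with a range from 0% to 12%.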

Compound 3, a percentage reported as inhibition, at one concentration (the size of the read-out at that concentration, not a potency): 0%
For compound 3 the middle estimate is 2 percentage points above the measured one; measured number inside the range.
By their numbers in this assay, from the lowest: compounds 1, 2 and 3 (each within the scatter of the next).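

Among these compounds, this is the first one-place step: with diethylsulfamoyl in place of 5-methyl-1,2,4-oxadiazol-3-yl on an aromatic carbon, meta to a large group, this assay shows no change at the digits printed from compound 1 to compound 3 (within the scatter). At this position, then, a group with no ring can take the place of a five-membered aromatic ring with 3 hetero atoms without moving the read-out beyond the scatter. Nothing at hand accounts for this result.

Still open, on these data alone, is whether any group on this aromatic carbon can lift the read-out in this assay clear of the scatter, for example a primary amine or a carboxylic acid. Also open, as far as these compounds go, is whether a change elsewhere on the shared core would do so, since this single step speaks only for the one position.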